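The source may report more compounds than this note shows. Statements on the series, on what has been measured and on what is new or still open speak of the compounds shown alone.

Compound 1 `CCCc1ncn2c(SC)nncc12` gives > 48000 nM in a functional assay for inhibition, with Homo sapiens as the target; on this read-out higher numbers stand for weaker inhibition and lower numbers for stronger inhibition.
Compound 2 `CCc1ncn2c(S)nncc12` gives > 48000 nM in this assay.
Compound 3 `CCc1ncn2c(O)nncc12` gives > 48000 nM in this assay.

Each of these values is a limit of this assay, not a number; for compound 2 only the limit > 48000 nM is known. Compound 4 `CCCc1ncn2c(S)nncc12` differs from compound 2 by methyl in place of hydrogen on a saturated chain carbon, two bonds along the chain from an aromatic carbon. Among the measured compounds shown here, the only measured step, a step that the two limits leave unreadable from compound 2 to compound 3, cannot be read, and compound 1 with the same propyl chain also reaches only a limit, > 48000 nM. Because every value sits at the limit of > 48000 nM in this assay, at which 3 of the 3 values shown sit, neither direction nor size of the change can be read. Compound 4 is therefore expected to stay at the limit, estimated at 60000 nM within 20000 nM to 200000 nM. The expected step that the limit leaves unreadable from compound 2 to compound 4 for compound 4 is none beyond the scatter.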

Compound 4, half-maximal inhibitory concentration: > 48000 nM
Compound 4: no number, only a limit (the forecaster's own chance of this, stated with the estimate: 85%); the middle value does not contradict the limit.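

Compound 4 gives > 48000 nM as a limit and not a number, so its steps from compound 1 and compound 2 cannot be read: the limit of > 48000 nM in this assay, at which 4 of the 4 values shown sit.

The compounds shown leave open what change to the shared core, if any, would give a measurable value in this assay at all.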